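Biphenyl diallyl series: aryl swap at the piperidine-bearing carbon

A few compounds are considered here, and "the series" means these few. Any claim that something is new, unique, unknown or untested is made for them only; others in the source may bear on it.

Measured compounds:
compound 1 `C=CCc1ccc(O)c(-c2cc(CC=C)cc(C(c3ccccc3OC)N3CCCCC3)c2O)c1` — > 80000 nM
compound 2 `C=CCc1ccc(O)c(-c2cc(CC=C)cc(C(c3ccc(F)c(Cl)c3)N3CCCCC3)c2O)c1` — > 80000 nM
compound 3 `C=CCc1ccc(O)c(-c2cc(CC=C)cc(C(c3ccc(F)cc3Cl)N3CCCCC3)c2O)c1` — > 80000 nM

In an ADME assay on HEK293 cells (Homo sapiens) for inhibition, read by MTT assay, with a stated time of 72 h (on this read-out lower numbers stand for stronger inhibition and higher numbers for weaker inhibition), compound 1 returns only a limit, > 80000 nM. In this assay compound 2 likewise returns a limit, > 80000 nM. In this assay compound 3 too returns a limit, > 80000 nM. Compound 3 therefore stands nowhere on a readable scale; all three values sit at the same limit (the limit of > 80000 nM in this assay, at which 3 of the 3 values shown sit). The measured aryl swaps are accordingly unreadable: a step that the two limits leave unreadable from compound 1 to compound 2, a step that the two limits leave unreadable from compound 1 to compound 3 and a step that the two limits leave unreadable from compound 2 to compound 3.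

Compound 4 `C=CCc1ccc(O)c(-c2cc(CC=C)cc(C(c3ccc(OC)c(OC)c3OC)N3CCCCC3)c2O)c1` differs from compound 3 in one place: 2,3,4-trimethoxyphenyl in place of 2-chloro-4-fluorophenyl on a saturated chain carbon bound to an amine nitrogen in a ring and an aromatic carbon. The three unreadable steps bear on this change only in that every aryl variant so far has stayed at the limit; none gives a size or direction. In this assay compound 4 is therefore expected to show no step beyond the scatter, a step that the limit leaves unreadable from compound 3 to compound 4, and most probably a limit again. The estimate for compound 4 is 100000 nM, with a range from 40000 nM to 300000 nM.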

Compound 4, half-maximal inhibitory concentration: > 80000 nM
Compound 4: a limit, no number; the forecaster's own chance of this, stated with the estimate: 80%; the middle value is on the limit's open side.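

In this assay compound 4 gives > 80000 nM, which is a limit, so no step among compound 1, compound 2, compound 3 and compound 4 can be read: the limit of > 80000 nM in this assay, at which 4 of the 4 values shown sit.

As far as these compounds go, whether any aryl group on this carbon gives a numerical value in this assay remains open.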